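The source may report more compounds than this note shows. Statements on the series, on what has been measured and on what is new or still open speak of the compounds shown alone.

Compound 1 `CC(C)[C@@H](NC(=O)c1cccc(F)c1)C(=O)N1CCC(c2ccc(Cl)cc2)CC1` is the strongest of the three compounds measured in an assay on THP-1 cells for displacement of a labelled ligand from C-C chemokine receptor type 1 (Homo sapiens) (a higher number here means a weaker inhibitor, a lower number a stronger inhibitor), where compound 1 gives 24 nM. Compound 2 `O=C(N[C@@H](C(=O)N1CCC(c2ccc(Cl)cc2)CC1)C1CCCCC1)c1ccccc1` gives 121 nM in this assay, and compound 3 `CC[C@@H](NC(=O)c1ccccc1)C(=O)N1CCC(c2ccc(Cl)cc2)CC1` gives 121 nM; both lie beyond the scatter from compound 1. The one step shown between single-point neighbours is no change at the digits printed from compound 2 to compound 3 (within the scatter), which changes the group on the saturated chain carbon and not the aryl carbonyl.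

Compound 4 `Cc1ccccc1C(=O)N[C@@H](C(=O)N1CCC(c2ccc(Cl)cc2)CC1)C(C)C` differs from compound 1 in one place: 2-methylphenyl in place of 3-fluorophenyl on a carbonyl carbon. For the measured compounds named here, no measured pair shows this change on its own. Compound 1 carries the 3-fluorophenyl together with an isopropyl on the chain carbon, while compound 2 and compound 3 carry an unsubstituted phenyl with other chain groups, so the aryl contribution cannot be separated from the values shown. The step from compound 2 to compound 3 bears only on the chain position and says nothing about the aryl ring.

Going by the values given here, with no direct precedent, compound 4 is expected to remain close to compound 1, with a modest weakening allowed by the lack of evidence, so its estimated step is a 1.7-fold higher number from compound 1 to compound 4 (0.22 log units; within the scatter). Compound 4 is therefore estimated at 40 nM, with a range of 12 nM to 130 nM.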

Compound 4, half-maximal inhibitory concentration: 32 nM
Beside the measured number, compound 4's estimate is 1.3-fold (0.10 log units) above it; the measured number falls inside the stated range.
By their numbers in this assay, from the lowest: compounds 1 and 4 (each within the scatter of the next); then compounds 2 and 3 (each within the scatter of the next).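

In this assay, placing 2-methylphenyl in place of 3-fluorophenyl on a carbonyl carbon gives a 1.3-fold higher number from compound 1 to compound 4 (0.12 log units; within the scatter), so the two aryl groups cannot be told apart in this assay. For the compounds shown here, this is the first direct reading at the aryl position, as the only earlier step, from compound 2 to compound 3, concerned the group on the saturated chain carbon. With isopropyl on that chain carbon, the aryl position thus accommodates a methyl-bearing ring as well as a fluorine-bearing one, with no measurable cost at this level of scatter, although no measurement offered here explains this result.

Compound 2 and compound 3 each differ from compound 1 and compound 4 in both the aryl group and the chain group, which leaves open how the gap in this assay divides between those two places. The compounds shown also leave open how an aryl ring carrying an amine or a carboxylic acid, or a longer chain such as n-butyl in place of isopropyl, would read in this assay.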